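Replacing 2-fluorophenyl with 2,4-dichlorophenyl in compound 3

This account rests on a few compounds, and the source may have more. Where it says the series, first, only, none or still open, it means among the compounds named here.

In a functional assay on MDA-MB-436 cells (Homo sapiens) for antiproliferative activity, read by MTT assay, with a stated time of 24 h (on this read-out lower numbers stand for stronger inhibition and higher numbers for weaker inhibition), compound 1 (`O=C(O)CC(NS(=O)(=O)c1ccccc1)c1ccccc1F`) gives > 100000 nM, which is a limit of the assay. Compound 2 (`N#Cc1ccc(S(=O)(=O)NC(CC(=O)O)c2ccccc2F)cc1`) gives 77700 nM, and compound 3 (`O=C(O)CC(NS(=O)(=O)c1cc(F)cc(F)c1)c1ccccc1F`) gives 89300 nM, two values within the scatter of each other. Compound 4 (`O=C(O)CC(NS(=O)(=O)c1cc(F)cc(F)c1)c1ccc(Cl)cc1Cl`) differs from compound 3 on a saturated chain carbon bound to a saturated chain carbon and a sulfonamide nitrogen: 2,4-dichlorophenyl in place of 2-fluorophenyl on a saturated chain carbon bound to a saturated chain carbon and a sulfonamide nitrogen. The measured steps, an at least 1.2-fold lower number from compound 1 to compound 2 (0.10 log units; that floor lies within the scatter), an at least 1.1-fold lower number from compound 1 to compound 3 (0.04 log units; that floor lies within the scatter) and a 1.1-fold higher number from compound 2 to compound 3 (0.06 log units; within the scatter), all change the sulfonyl side and lie within the scatter. None tests this place, so only a modest change is expected: a 1.6-fold lower number from compound 3 to compound 4 (0.21 log units; within the scatter). For compound 4, the estimated value is 55000 nM, with an expected range of 20000 nM to 130000 nM.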

Compound 4, half-maximal inhibitory concentration: 49600 nM
Beside the measured number, compound 4's estimate is 1.1-fold (0.04 log units) above it, within the range that was stated.
By their numbers in this assay, from the lowest: compounds 4, 2 and 3 (each within the scatter of the next). At a limit, above all of these: compound 1.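

In this assay, the only step shown at the saturated chain carbon bound to a saturated chain carbon and a sulfonamide nitrogen is a 1.8-fold lower number from compound 3 to compound 4 (0.26 log units; within the scatter). Like the changes on the sulfonyl side, this change to the aryl group at a second place does not move the number beyond the scatter. Compound 1 alone stands at a limit of the assay: the limit of > 100000 nM in this assay, at which 1 of the 4 values shown sits.

The compounds shown leave open whether an amine at this place, or an amide in place of the carboxylic acid, would move the number beyond the scatter.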